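The compounds below may be only part of what the source reports. "The series", "measured", "known", "first", "only" and "open" are said of these compounds alone.

Working notes on the series. Compound 1 `CN(C)CCN1CCN(CC(=O)Nc2ccc(-c3nc4cc(F)ccc4o3)cc2)CC1` is measured in a functional assay on MCF7 cells (Homo sapiens) for cytotoxicity, read by MTT assay, with a stated time of 24 h (on this read-out higher numbers stand for weaker inhibition and lower numbers for stronger inhibition), where compound 1 gives 20800 nM. Its only neighbour among the numbers shown is compound 2 `Cc1cc(-c2nc3cc(F)ccc3o2)ccc1NC(=O)CN1CCN(CCN(C)C)CC1`, which in this assay gives 10400 nM; the step of a 2.0-fold lower number from compound 1 to compound 2 (0.30 log units; within the scatter), methyl in place of hydrogen on an aromatic carbon, falls within the scatter, so the two compounds are not separated on this read-out.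

Compound 3 `CN(C)CCN1CCN(CC(=O)Nc2ccc(-c3nc4cc(Cl)ccc4o3)cc2)CC1` differs from compound 1 by chloro in place of fluoro on an aromatic carbon. Among the compounds with values here, no measured step touches this position or exchanges one halogen for another; the only step available is the methyl change from compound 1 to compound 2, which was itself within the scatter. With nothing in the data pointing to a shift, the step for compound 3 is expected to be a 1.2-fold lower number from compound 1 to compound 3 (0.06 log units; within the scatter), that is, no change beyond the scatter. Compound 3 is therefore estimated in this assay at 18000 nM, with a range of 8000 nM to 40000 nM.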

Compound 3, half-maximal inhibitory concentration: 7920 nM
The estimate for compound 3 lay 2.3-fold (0.36 log units) above the measured number, outside the stated range (below it).
By their numbers in this assay, from the lowest: compounds 3, 2 and 1 (each within the scatter of the next, the first and the last beyond it).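

In this assay, within the data shown here, the exchange at the halogen gives a 2.6-fold lower number from compound 1 to compound 3 (0.42 log units; beyond the scatter) and so is the first single change here to pass the scatter, though only modestly. The methyl change, with a 2.0-fold lower number from compound 1 to compound 2 (0.30 log units; within the scatter), did not separate its pair, so the halogen on this six-membered aromatic ring is the only place shown where a single exchange moves the number beyond the scatter. No measurement at hand accounts for the shift.

As far as these compounds go, whether bromo, a methoxy group or an amine at this position would move the number further in the same direction remains open, as does the effect of plain hydrogen there. Also open, from the compounds shown here alone, is whether chloro in place of fluoro gives a similar step when the methyl of compound 2 is present.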